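The source may hold more compounds than are shown below. What is called first, only, known or untested is meant among the compounds shown, and "the series" means these compounds.

In a functional assay on NCI-H1975 cells (Homo sapiens) for inhibition, read by sulforhodamine B assay, with a stated time of 48 h (a lower number here means a stronger inhibitor of growth, a higher number a weaker inhibitor of growth), compound 1 `CC(C)c1cc(C(=O)Nc2cccc(NC(=O)CCCCCCC(=O)NO)c2)c(O)cc1O` reports only a limit, > 10000 nM. Compound 3 `CC(C)c1cc(C(=O)Nc2ccccc2NC(=O)CCCCCCC(=O)NO)c(O)cc1O` also reports only a limit, > 10000 nM. For the measured compounds named here, compound 2 `CC(C)c1cc(C(=O)N(C)c2ccc(NC(=O)CCCCCCCCC(=O)NO)cc2)c(O)cc1O` gives 210 nM, the only true number among the three compounds measured so far. Compound 4 `CC(C)c1cc(C(=O)N(C)c2ccc(NC(=O)CCCCCCC(=O)NO)cc2)c(O)cc1O` departs from compound 2 on a saturated chain carbon, six bonds along the chain from a carbonyl carbon: hydroxycarbamoyl in place of 2-(hydroxycarbamoyl)ethyl on a saturated chain carbon, six bonds along the chain from a carbonyl carbon. Going by the values given here, no measured pair shows this change on its own, so any forecast starts from compound 2 at 210 nM. A modest weakening of growth inhibition is expected, the estimated step being a 2.1-fold higher number from compound 2 to compound 4 (0.33 log units; beyond the scatter). For compound 4 the expected value is 450 nM, with an estimated range of 130 nM to 1800 nM.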

Compound 4, concentration for 50% growth inhibition: 690 nM
Estimate against measurement, compound 4: 1.5-fold (0.19 log units) below, within the range that was stated.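

In this assay, for the compounds shown here, hydroxycarbamoyl in place of 2-(hydroxycarbamoyl)ethyl gives a 3.3-fold higher number from compound 2 to compound 4 (0.52 log units; beyond the scatter), the only step here between two true numbers. It shows that growth inhibition responds to chain length at this place, while the shorter chain of compound 4 still gives a true number, 690 nM. Steps to the other compounds cannot be read: the limit of > 10000 nM in this assay, at which 2 of the 4 values shown sit.

On these data alone, whether a longer chain than that of compound 2 would lower the number further remains open. So does the effect of a carboxylic acid in place of hydroxycarbamoyl.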